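The compounds below may be only part of what the source reports. "The series", "measured", "known", "first", "only" and "open" are said of these compounds alone.

Measured so far:
- compound 1 `COc1ccc(-c2nc3cc(F)ccc3s2)cc1F`: 13700 nM
- compound 2 `COc1ccc(-c2nc3cc(F)ccc3s2)cc1Br`: 3450 nM

Both values come from a functional assay on HCC 2998 cells (Homo sapiens) for antiproliferative activity; on this read-out lower numbers stand for stronger inhibition of growth and higher numbers for weaker inhibition of growth. Compound 2 has the lower of the two numbers, and its gap to compound 1 lies beyond the scatter.

The next compound is compound 3 `COc1ccc(-c2nc3cc(F)ccc3s2)cc1I`, which differs from compound 2 at one place: iodo in place of bromo on an aromatic carbon. This is iodo in place of bromo on an aromatic carbon, ortho to a methoxy group.

Within the data shown here, only one measured step bears on this change: a 4.0-fold lower number from compound 1 to compound 2 (0.60 log units; beyond the scatter). That modest step, bromo in place of fluoro, lies beyond the scatter. Among the measured compounds shown here, a single step does not establish a trend, and the series has no measured iodo compound to test one. The direction of that step still points to a further small fall in the number in this assay, although a result within the scatter of compound 2 would be unsurprising.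

The expected change is a 1.4-fold lower number from compound 2 to compound 3 (0.14 log units; within the scatter). For compound 3 the estimated value is 2500 nM, with an expected range of 1000 nM to 6000 nM.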

Compound 3, concentration for 50% growth inhibition: 940 nM
Compound 3: middle estimate off by 2.7-fold (0.42 log units), on the high side, outside the stated range (below it).
By their numbers in this assay, from the lowest: compound 3; then compound 2; then compound 1.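

Iodo in place of bromo, on the aromatic carbon ortho to a methoxy group, continues in the direction of the earlier change: this assay shows a 3.7-fold lower number from compound 2 to compound 3 (0.56 log units; beyond the scatter) and this follows a 4.0-fold lower number from compound 1 to compound 2 (0.60 log units; beyond the scatter) with both steps beyond the scatter. Fluoro, bromo and iodo at this one place therefore form an ordered run across compound 1, compound 2 and compound 3, with no compound among the three going against it, and the full span of a 15-fold lower number from compound 1 to compound 3 (1.16 log units; beyond the scatter) is large where the first step alone was modest. No measurement among those given accounts for this order.

As far as these compounds go, whether the run reflects the halogens as a set remains open, since chloro at this place would be needed to fill the gap between fluoro and bromo, while a hydrogen, a methyl, a nitrile or an amine there would show whether a group other than a halogen fits the same order. Also open, from the compounds shown here alone, is whether the order holds with the methoxy group replaced by a hydroxyl or an ethoxy group, and in cells other than those of this assay.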